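Swapping the sulfonyl cap for an acetyl on a shared core

A few compounds are considered here, and "the series" means these few. Any claim that something is new, unique, unknown or untested is made for them only; others in the source may bear on it.

Of the compounds shown here, two have been tested in an assay on cells for inhibition of cytochrome P450 11B2, mitochondrial (Homo sapiens), read by HTRF; a lower number here means a stronger inhibitor, a higher number a weaker inhibitor. Compound 1, `CC(=O)N[C@@H]1CCCc2c1cncc2N1C(=O)c2ccc(Cl)cc2[C@@H]1C`, gives 4 nM. Compound 2, `CCS(=O)(=O)N[C@@H]1CCCc2c1cncc2N1Cc2cc(Cl)ccc2C1=O`, gives 40 nM. Among the two measured values, compound 2 has the higher number, and its nearest neighbour, compound 1, stands lower by a gap that lies beyond the usual scatter. Compound 1 and compound 2 differ in more than one place, so the numbers alone do not say which part of the structure accounts for that gap.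

Compound 3, `CC(=O)N[C@@H]1CCCc2c1cncc2N1Cc2cc(Cl)ccc2C1=O`, keeps the core of compound 2 and changes only the group on the amine nitrogen: acetyl in place of ethylsulfonyl on an amine nitrogen. The new group is the same acetyl that compound 1 carries. Going by the values given here, no single-change step between measured compounds is available for this change, so the expected size of the step in this assay is uncertain, though a move toward a lower number seems somewhat more likely than a move to a higher one. The estimated step from compound 2 to compound 3 is a 2.0-fold lower number from compound 2 to compound 3 (0.30 log units; within the scatter). Compound 3 is therefore expected to give about 20 nM, within a range from 5 nM to 80 nM.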

Compound 3, half-maximal inhibitory concentration: 44 nM
Estimate against measurement, compound 3: 2.2-fold (0.34 log units) below; low and high end bracket the measured number.
By their numbers in this assay, from the lowest: compound 1; then compounds 2 and 3 (each within the scatter of the next).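

Putting acetyl in place of ethylsulfonyl on an amine nitrogen gives, in this assay, a 1.1-fold higher number from compound 2 to compound 3 (0.04 log units; within the scatter) and so, on this core, the two groups cannot be told apart. Compound 3 also provides the single-change comparison that the first two compounds lacked: with acetyl on the nitrogen in both compounds, hydrogen in place of methyl on a saturated ring carbon gives an 11-fold higher number from compound 1 to compound 3 (1.04 log units; beyond the scatter) and this large step lies well beyond the scatter. Among these three compounds, the gap between compound 1 and compound 2 therefore tracks the methyl group on that ring carbon, not the choice of group on the nitrogen. Nothing available here offers an explanation for either result.

The compounds shown leave open whether the methyl group would bring a similar step with ethylsulfonyl on the nitrogen, and whether an ethyl group on the same ring carbon would match the methyl. They also leave open how a bare amine, with neither acetyl nor ethylsulfonyl on the nitrogen, would compare.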